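A few compounds are considered here, and "the series" means these few. Any claim that something is new, unique, unknown or untested is made for them only; others in the source may bear on it.

Measured compounds:
Compound 1 `Cc1cc(-c2nc3cc(F)ccc3o2)ccc1NC(=O)CCl` gives 25400 nM in a functional assay on HT-29 cells (Homo sapiens) for cytotoxicity, read by MTT assay, with a stated time of 24 h; a higher number here means a weaker inhibitor, a lower number a stronger inhibitor.
Compound 2 `Cc1cc(-c2nc3ccccc3o2)ccc1NC(=O)CN1CCN(CCCN(C)C)CC1` gives 15500 nM in this assay.
Compound 3 `Cc1cc(-c2nc3ccccc3o2)ccc1NC(=O)CCl` gives 13800 nM in this assay.

Compound 3 and compound 1 share a core and differ by one change, (fluoro in place of hydrogen on an aromatic carbon). In this assay this change gives a 1.8-fold higher number from compound 3 to compound 1 (0.26 log units; within the scatter), so the two numbers are not told apart by this assay. Compound 2 carries the same core as compound 3 with a different amide substituent; the difference between the two cores is not broken down here. The values of compound 2 and compound 3 lie within the scatter of each other, as do those of compound 2 and compound 1, so none of the three can be ranked.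

Compound 4 `Cc1cc(-c2nc3cc(F)ccc3o2)ccc1NC(=O)CN1CCN(CCCN(C)C)CC1` is not yet measured. It stands to compound 2 as compound 1 stands to compound 3: the change is fluoro in place of hydrogen on an aromatic carbon, the same kind of change as before, at a place described in the same words. Going by the values given here, only one earlier instance exists, and it fell within the scatter.

Among the compounds with values here, the expectation for compound 4 in this assay is therefore a step of a 1.4-fold higher number from compound 2 to compound 4 (0.15 log units; within the scatter), resting on the single earlier step of a 1.8-fold higher number from compound 3 to compound 1 (0.26 log units; within the scatter), with wide bounds because that step is within the scatter. Compound 4 is estimated at 22000 nM, between 9000 nM and 55000 nM.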

Compound 4, half-maximal inhibitory concentration: 6700 nM
For compound 4 the middle estimate is 3.3-fold (0.52 log units) above the measured one; measured number outside the range, below it.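

In this assay, fluoro in place of hydrogen on an aromatic carbon, 1,3-benzoxazol-2-yl becoming 5-fluoro-1,3-benzoxazol-2-yl, gives a 2.3-fold lower number from compound 2 to compound 4 (0.36 log units; beyond the scatter), a modest step on the core that carries the longer amide substituent. This change therefore cannot be carried as one fixed step between the two cores, and a step read on one core is a poor guide to the other, since the two differ by more than the scatter allows: the same change on two cores in this assay, a 1.8-fold higher number (0.26 log units; within the scatter) from compound 3 to compound 1 and a 2.3-fold lower number (0.36 log units; beyond the scatter) from compound 2 to compound 4, 4.3-fold (0.63 log units) apart, beyond the scatter of two such steps

Going by these compounds alone, only two pairs stand behind this, and one of the two steps lies within the scatter, so the result shows a dependence on the core for these two pairs only; it gives no general rule for the series, no firm opposite direction of the change on the two cores, and no cause for the gap.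

The compounds shown leave open which of the two steps a third amide substituent would follow, for example a simple primary amine or a carboxylic acid in place of the chlorine atom. They also leave open whether chloro or methoxy on the same aromatic carbon would depend on the core in the same way as fluoro.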